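The compounds below may be only part of what the source reports. "The series", "measured", "known", "first", "only" and "open" are said of these compounds alone.

Measured compounds:
compound 1 `CC1(C)C[C@H](CN([C@H](CCC(F)(F)F)C(N)=O)S(=O)(=O)c2ccc(Cl)cc2)O1`, in an in vitro ADME assay on microsomes from liver (Homo sapiens) for metabolic stability, read by HPLC (on this read-out higher numbers stand for fast clearance and lower numbers for slow clearance), compound 1 gives 29 mL/min/kg
compound 2 `CC1(C)CO[C@H]1CN([C@H](CCC(F)(F)F)C(N)=O)S(=O)(=O)c1ccc(Cl)cc1`, in this assay compound 2 gives 262 mL/min/kg

Compound 2 stands highest of the two numbers; its nearest neighbour is compound 1, and the step of a 9.0-fold higher number from compound 1 to compound 2 (0.96 log units; beyond the scatter) separates them. Compound 3 `NC(=O)[C@@H](CCC(F)(F)F)N(CC1CCCC1)S(=O)(=O)c1ccc(Cl)cc1` is the next compound, not yet measured. It differs from compound 2 by cyclopentyl in place of 3,3-dimethyloxetan-2-yl on a saturated chain carbon bound to a sulfonamide nitrogen. For the measured compounds named here, only one measured step exists, and it swaps one dimethyloxetanyl isomer for the other rather than removing the oxetane ring altogether, so it does not speak directly to this change. That step was nonetheless sizeable, showing that this position can move the number well beyond the scatter. With no measurement of a carbon-only ring at this place, the direction of the step of a 1.7-fold lower number from compound 2 to compound 3 (0.24 log units; within the scatter) is expected to be uncertain, and the estimate for compound 3 is set a little below compound 2 with a wide range: compound 3 is expected to give about 150 mL/min/kg, between 40 mL/min/kg and 500 mL/min/kg.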

Compound 3, clearance: 229 mL/min/kg
Compound 3: the middle estimate sits 1.5-fold (0.18 log units) below what was measured; the measured number falls inside the stated range.
By their numbers in this assay, from the lowest: compound 1; then compounds 3 and 2 (each within the scatter of the next).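

Replacing 3,3-dimethyloxetan-2-yl with the carbon-only cyclopentyl ring leaves the clearance reading in this assay within the usual scatter (a 1.1-fold lower number from compound 2 to compound 3 (0.06 log units; within the scatter)), so in this pair the presence or absence of a ring oxygen makes no clear difference. Compound 1 now stands apart from two differently built groups, as the same place gives a clearly separated number when its 4,4-dimethyloxetan-2-yl group gives way to cyclopentyl (a 7.9-fold higher number from compound 1 to compound 3 (0.90 log units; beyond the scatter)). Nothing available here explains why the 4,4-dimethyloxetan-2-yl group stands apart.

From the compounds shown here alone, it remains open whether an oxetan-2-yl ring without its two methyl groups would read like compound 1 or like compound 3. Also open, going by these compounds, is where a cyclohexyl ring, a longer open chain or an amine at this place would fall.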